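This account rests on a few compounds, and the source may have more. Where it says the series, first, only, none or still open, it means among the compounds named here.

Measured in a functional assay on L6 cells (Rattus norvegicus) for inhibition; on this read-out higher numbers stand for weaker inhibition and lower numbers for stronger inhibition:
- Compound 1 `Cc1ccc(CNC(=O)c2nn(-c3ccc(F)cc3)c(CC[C@@H](O)C[C@@H](O)CC(=O)O)c2C(C)C)cc1`: 800 nM
- Compound 2 `CC(C)c1c(C(=O)N2CCC[C@H](c3ccccc3)C2)nn(-c2ccc(F)cc2)c1CC[C@@H](O)C[C@@H](O)CC(=O)O`: 310 nM
- Compound 3 `CC(C)c1c(C(=O)NCC2CCCCC2)nn(-c2ccc(F)cc2)c1OC[C@@H](O)C[C@@H](O)CC(=O)O`: "not determined" (no result reported)

Compound 3 has no number in this assay, so the step to compound 4 `CC(C)c1c(C(=O)N2CCCCC2)nn(-c2ccc(F)cc2)c1OC[C@@H](O)C[C@@H](O)CC(=O)O` has no measured starting point. The change is piperidin-1-yl in place of (cyclohexylmethyl)amino on a carbonyl carbon, with piperidin-1-yl in place of (cyclohexylmethyl)amino on a carbonyl carbon. For the measured compounds named here, the one measured step that bears on it is a 2.6-fold lower number from compound 1 to compound 2 (0.41 log units; beyond the scatter), where 3-phenylpiperidin-1-yl replaces (4-methylbenzyl)amino at that same carbonyl carbon. That step was modest, so a modest move to a lower number is the most that can be expected, and only tentatively. Going by the values given here, compounds 3 and 4 share a core that differs from that of compounds 1 and 2, and no compound with their core has a number yet. Compound 4 is expected near 500 nM, with an estimated range of 100 nM to 2500 nM.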

Compound 4, half-maximal inhibitory concentration: 32200 nM
For compound 4 the middle estimate is 64-fold (1.81 log units) below the measured one; measured number outside the range, above it.
By their numbers in this assay, from the lowest: compound 2; then compound 1; then compound 4.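

Compound 3 has no number in this assay, so the step from it to compound 4 cannot be read. The compounds shown leave open whether the piperidin-1-yl group or the core shared by compound 3 and compound 4 sets the value of compound 4, 32200 nM. Nothing available here explains that value.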